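Leucine-to-valine swap on a thiazolidinedione cinnamide scaffold

The source may report more compounds than this note shows. Statements on the series, on what has been measured and on what is new or still open speak of the compounds shown alone.

Measured so far, in a functional assay on RAW264.7 cells (Mus musculus) for inhibition, read by microscopy and resazurin assay, with a stated time of 72 h; a higher number here means a weaker inhibitor, a lower number a stronger inhibitor:
compound 1, `COC(=O)[C@H](CC(C)C)NC(=O)c1ccc(/C=C2\SC(=O)N(CC(=O)NOCc3ccccc3)C2=O)cc1`: > 128000 nM, a limit of the assay
compound 2, `C=CCONC(=O)CN1C(=O)S/C(=C\c2cccc(C(=O)N[C@@H](CC(C)C)C(=O)OC)c2)C1=O`: > 128000 nM, a limit of the assay
compound 3, `COC(=O)[C@@H](NC(=O)c1ccc(/C=C2\SC(=O)N(CC(=O)NOCc3ccccc3)C2=O)cc1)C(C)C`: > 128000 nM, a limit of the assay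

Compounds 1 and 3 share a core, and compound 3 carries isopropyl in place of isobutyl on a saturated chain carbon bound to an amide-type nitrogen and a carbonyl carbon. Since both sit at a limit, a step that the two limits leave unreadable from compound 1 to compound 3, and the step cannot be read. All three values shown rest at the limit of > 128000 nM in this assay, at which 3 of the 3 values shown sit. The difference between the core of compound 2 and that of compound 1 is not broken down here.

Compound 4, `C=CCONC(=O)CN1C(=O)S/C(=C\c2cccc(C(=O)N[C@H](C(=O)OC)C(C)C)c2)C1=O`, has not yet been measured in this assay. It differs from compound 2 by isopropyl in place of isobutyl on a saturated chain carbon bound to an amide-type nitrogen and a carbonyl carbon, which is the same change as that from compound 1 to compound 3. On that basis the step from compound 2 to compound 4 is expected to be a step that the limit leaves unreadable from compound 2 to compound 4, with no measurable shift anticipated. Compound 4 is therefore estimated at 200000 nM, most likely reported again as a limit rather than a number, between 100000 nM and 1000000 nM.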

Compound 4, half-maximal inhibitory concentration: > 128000 nM
Compound 4: only a limit was reported; the forecaster's own chance of this, stated with the estimate: 90%; the middle value does not contradict the limit.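

In this assay compound 4 gives > 128000 nM, a limit of the assay. Among these compounds, compound 2 also stands at a limit, so no step from isobutyl to isopropyl can be read between compound 2 and compound 4. The compounds shown leave open whether this change alters inhibition at all, and how strongly any of them inhibits, with every value resting at one point: the limit of > 128000 nM in this assay, at which 4 of the 4 values shown sit.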